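This account rests on a few compounds, and the source may have more. Where it says the series, first, only, none or still open, it means among the compounds named here.

Compound 1 `CC/C=C/C(=O)Nc1cccc(Oc2nc(Nc3cccc(OC)c3)nc3ccsc23)c1` and compound 2 `CCC/C=C/C(=O)Nc1cccc(Oc2nc(Nc3cccc(OC)c3)nc3ccsc23)c1` share one core and differ by methyl in place of hydrogen on a saturated chain carbon, two bonds along the chain from a double-bonded chain carbon. In a functional assay on MCF7 cells (Homo sapiens) for inhibition, read by MTT assay, with a stated time of 72 h (a higher number here means a weaker inhibitor, a lower number a stronger inhibitor), compound 1 gives 43400 nM, and compound 2 gives 5020 nM, so that the step is an 8.6-fold lower number from compound 1 to compound 2 (0.94 log units; beyond the scatter). Compound 3 `CC/C=C/C(=O)Nc1cccc(Oc2nc(Nc3cccc(C#N)c3)nc3ccsc23)c1` carries a different core, set apart from compound 1 by cyano in place of methoxy on an aromatic carbon. In this assay compound 3 gives > 50000 nM, which is a limit of the measurement rather than a number, and that is the limit of > 50000 nM in this assay, at which 1 of the 3 values shown sits. Compound 4 `CC(C)/C=C/C(=O)Nc1cccc(Oc2nc(Nc3cccc(C#N)c3)nc3ccsc23)c1` has not yet been measured in this assay and differs from compound 3 by methyl in place of hydrogen on a saturated chain carbon bound to a double-bonded chain carbon and a saturated chain carbon. This is the same kind of change as that from compound 1 to compound 2, not the same: there the methyl sits two bonds along the chain from a double-bonded chain carbon, here on a saturated chain carbon bound to a double-bonded chain carbon and a saturated chain carbon. Because the step of an 8.6-fold lower number from compound 1 to compound 2 (0.94 log units; beyond the scatter) lowered the number, compound 4 is expected to give about 20000 nM, somewhere between 5000 nM and 50000 nM. The expected step is an at least 2.5-fold lower number from compound 3 to compound 4 (0.39 log units; beyond the scatter), and it rests on that single measured example of such a change, starting from a value that is only a limit.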

Compound 4, half-maximal inhibitory concentration: > 50000 nM
Compound 4 ended at the assay's limit; the forecaster's own chance of this, stated with the estimate: 35%; at least 2.5-fold (0.39 log units) between middle value and limit.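

Compound 3 and compound 4 both stand at a limit of this assay, not at a number, so no step between them can be read: the limit of > 50000 nM in this assay, at which 2 of the 4 values shown sit.

The compounds shown leave open whether this added methyl changes the number in this assay at all, on this core or on the core of compound 1.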